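The compounds below may be only part of what the source reports. "The series", "measured", "known", "first", "only" and "open" are said of these compounds alone.

In a physicochemical assay for permeability, using PAMPA, with a stated time of 4 h, at pH 7.4, tested at 50 uM (a lower number here means that the compound crosses the layer more slowly, a higher number that the compound crosses the layer faster), the measured compounds stand as follows:

Compound 1 `Cc1c(F)cccc1CCCCOc1ccc(C#Cc2cccc3c(CCCC(=O)O)c(C)n(CCCC(=O)O)c23)cc1` gives 12.4 10^-6 cm/s.
Compound 2 `O=C(O)CCCc1cn(CC(=O)O)c2c(/C=C/c3ccc(OCCCCc4c(F)ccc(F)c4F)cc3)cccc12` gives < 0.05 10^-6 cm/s.
Compound 3 `Cc1c(Cl)cccc1CCCCOc1ccc(C#Cc2cccc3c(CCCC(=O)O)c(C)n(CCC(=O)O)c23)cc1` gives 3 10^-6 cm/s.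

The value for compound 2 is a limit of the assay and not a number. Going by the values given here, compound 2 is the single compound that sits at the limit of < 0.05 10^-6 cm/s in this assay, at which 1 of the 3 values shown sits, and among the three measured compounds it is the only one for which this assay reports no number at all. Compound 1 and compound 3 carry a different core and different acid chains, so their values say nothing direct about the change that follows.

Compound 4 `Cc1c(F)cccc1CCCCOc1ccc(/C=C/c2cccc3c(CCCC(=O)O)cn(CC(=O)O)c23)cc1` keeps the core of compound 2 and differs from it only at the far end of the chain: 3-fluoro-2-methylphenyl in place of 2,3,6-trifluorophenyl on a saturated chain carbon, four bonds along the chain from an oxygen on an aromatic ring. Among the compounds with values here, no measured pair shows this exact change, so the size of the step is not known. Since the core and both acid groups are unchanged, the expected step of an at least 2.0-fold higher number from compound 2 to compound 4 (0.30 log units; that floor lies within the scatter) is small, with the likeliest outcome being that compound 4 again sits at or close to the limit in this assay. Compound 4 is therefore estimated at 0.1 10^-6 cm/s, with a range from 0.03 10^-6 cm/s to 0.6 10^-6 cm/s.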

Compound 4, apparent permeability: < 0.05 10^-6 cm/s
Compound 4: only a limit was reported; the forecaster's own chance of this, stated with the estimate: 55%; middle value at least 2.0-fold (0.30 log units) from the limit.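

In this assay compound 4 gives < 0.05 10^-6 cm/s as a limit of the assay and not a number. Compound 2 gives < 0.05 10^-6 cm/s as a limit as well. Going by these compounds alone, no step can therefore be read between compound 2 and compound 4. The compounds shown leave open whether 3-fluoro-2-methylphenyl in place of 2,3,6-trifluorophenyl changes the read-out at all, with both values resting on the same limit: the limit of < 0.05 10^-6 cm/s in this assay, at which 2 of the 4 values shown sit.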